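A few compounds are considered here, and "the series" means these few. Any claim that something is new, unique, unknown or untested is made for them only; others in the source may bear on it.

Working notes on the series. The shared core is that of compound 1 `C=C1C[C@]23C[C@@]1(O)CC[C@H]2c1cc(Br)c(O)c(C)c1[C@@H]3Cn1cc(-c2ccccc2)nn1`; compound 2 `C=C1C[C@]23C[C@@]1(O)CC[C@H]2c1cc(Br)c(O)c(C)c1[C@@H]3Cn1cc(-c2ccc(Cl)cc2)nn1` and compound 3 `C=C1C[C@]23C[C@@]1(O)CC[C@H]2c1cc(Br)c(O)c(C)c1[C@@H]3Cn1cc(-c2ccc(OC)cc2)nn1` carry a chloro or a methoxy on the phenyl of the triazole, and compound 4 `C=C1C[C@]23C[C@@]1(O)CC[C@H]2c1ccc(O)c(C)c1[C@@H]3Cn1cc(-c2ccc(Cl)cc2)nn1` is not yet measured. Going by the values given here, in a functional assay on MCF7 cells (Homo sapiens) for cytotoxicity, read by MTT assay, with a stated time of 4 days (a higher number here means a weaker inhibitor, a lower number a stronger inhibitor), compound 2 gives 10200 nM, the only number among the three values. For compound 1 this assay reports a limit, > 20000 nM. For compound 3 it also reports a limit, > 20000 nM. The steps that follow from these are accordingly an at least 1.9-fold lower number from compound 1 to compound 2 (0.29 log units; that floor lies within the scatter) and an at least 1.9-fold higher number from compound 2 to compound 3 (0.29 log units; that floor lies within the scatter), while a step that the two limits leave unreadable from compound 1 to compound 3; all of this rests on (the limit of > 20000 nM in this assay, at which 2 of the 3 values shown sit).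

Compound 4 differs from compound 2 by hydrogen in place of bromo on an aromatic carbon. Among the compounds with values here, none of the measured steps touches this position: the three measured compounds all carry the bromo, and they differ only in the substituent on the phenyl of the triazole. Within the data shown here, there is therefore no measured step that bears on the change from compound 2 to compound 4, and no basis for expecting a step beyond the scatter in either direction in this assay. The number for compound 4 is estimated at 10000 nM, with a range from 3500 nM to 20000 nM, which corresponds to an expected step of a 1.0-fold lower number from compound 2 to compound 4 (0.01 log units; within the scatter).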

Compound 4, half-maximal inhibitory concentration: > 20000 nM
Compound 4 was reported as a limit (the forecaster's own chance of this, stated with the estimate: 35%); middle value at least 2.0-fold (0.30 log units) away from the limit.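

The position on the aromatic ring of the fused system, ortho to a hydroxy group, now has a reading of its own: in this assay, hydrogen in place of bromo gives an at least 1.9-fold higher number from compound 2 to compound 4 (0.29 log units; that floor lies within the scatter). The earlier compounds shown here all carried the bromo and differed only on the phenyl of the triazole, so they said nothing about this position; here the chloro on that phenyl is held constant and only the bromo changes. Compound 4 is reported as a limit, so only the floor of the step can be read, and its true size stays unknown: the limit of > 20000 nM in this assay, at which 3 of the 4 values shown sit.

The compounds shown leave open whether the step from bromo to hydrogen truly lies beyond the scatter, and whether it would look the same with the plain phenyl or the methoxy-bearing phenyl on the triazole. They also leave open how an amine, a carboxylic acid or a longer chain such as ethyl in place of bromo would read in this assay.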